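A few compounds are considered here, and "the series" means these few. Any claim that something is new, unique, unknown or untested is made for them only; others in the source may bear on it.

Compound 1 `CCCC[C@H](CCn1cncn1)c1ccc(Cl)cc1` and compound 2 `CCCC[C@@H](CCn1cncn1)c1ccc(Cl)cc1` are the two measured compounds. In an ADME assay on RD cells (Homo sapiens) for cytotoxicity, read by MTT assay, with a stated time of 3 days (a higher number here means that more compound is tolerated, a lower number that less compound is tolerated), compound 1 gives 20.3 ug/mL and compound 2 gives 18.7 ug/mL; the step of a 1.1-fold lower number from compound 1 to compound 2 (0.04 log units; within the scatter) lies within the scatter, in keeping with the fact that compounds 1 and 2 differ only in the configuration as drawn. Compound 2 stands lowest of the two numbers, with compound 1 nearest and within the scatter. Compound 3 `CCCC[C@@H](CCn1cncn1)c1ccc(Cl)cc1Cl` differs from compound 2 by chloro in place of hydrogen on an aromatic carbon. Going by the values given here, no measured step adds a chloro group; the one measured step concerns configuration alone and does not bear on this change. The expected step, a 1.2-fold lower number from compound 2 to compound 3 (0.10 log units; within the scatter), is therefore none beyond the scatter. Compound 3 is estimated at 15 ug/mL, between 7 ug/mL and 30 ug/mL.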

Compound 3, half-maximal cytotoxic concentration: 1.9 ug/mL
The estimate for compound 3 lay 7.9-fold (0.90 log units) above the measured number; measured number outside the range, below it.
By their numbers in this assay, from the lowest: compound 3; then compounds 2 and 1 (each within the scatter of the next).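

In this assay, chloro in place of hydrogen on an aromatic carbon, ortho to a large group and meta to a chloro group, gives a 9.8-fold lower number from compound 2 to compound 3 (0.99 log units; beyond the scatter) and so moves the number beyond the scatter, which the earlier step in configuration alone did not do. This position therefore responds strongly to a single added chlorine atom, at least with the configuration of compound 2. Nothing given here bears on why the number falls. As far as these compounds go, whether the opposite configuration responds in the same way remains open. So does whether a methyl, a methoxy or an amine at this position would give a step of similar size.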